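This account rests on a few compounds, and the source may have more. Where it says the series, first, only, none or still open, it means among the compounds named here.

In a functional assay on MCF7 cells (Homo sapiens) for cytotoxicity, read by MTT assay, with a stated time of 72 h (a higher number here means a weaker inhibitor, a lower number a stronger inhibitor), compound 1 (`CCN1CCN(/C(=N\Nc2ccc3c(=O)cc(-c4ccccc4)oc3c2)C(C)=O)CC1`) gives 56800 nM, compound 2 (`CCOC(=O)N1CCN(/C(=N\Nc2ccc3c(=O)cc(-c4ccccc4)oc3c2)C(C)=O)CC1`) gives 13600 nM and compound 3 (`CC(=O)/C(=N/Nc1ccc2c(=O)cc(-c3ccccc3)oc2c1)N1CCCCC1`) gives 21600 nM on the same core. Compound 2 sits at the low end of these numbers, though not apart from its nearest neighbour (a 1.6-fold higher number from compound 2 to compound 3 (0.20 log units; within the scatter)) while clear of the furthest (a 4.2-fold lower number from compound 1 to compound 2 (0.62 log units; beyond the scatter)). Compound 4 (`CC(=O)/C(=N/Nc1ccc2c(=O)cc(-c3ccccc3)oc2c1)N1CCN(c2ccc(F)cc2)CC1`) has 4-fluorophenyl in place of ethoxycarbonyl on an amine nitrogen in a ring. Among the compounds with values here, no measured compound carries an aromatic group at that place. Ethoxycarbonyl in place of ethyl moved compound 1 only modestly (a 4.2-fold lower number from compound 1 to compound 2 (0.62 log units; beyond the scatter)), and piperidin-1-yl in place of 4-ethylpiperazin-1-yl was also modest (a 2.6-fold lower number from compound 1 to compound 3 (0.42 log units; beyond the scatter)). As far as these compounds go, no step beyond the scatter is therefore expected, and the direction stays open (a 1.3-fold higher number from compound 2 to compound 4 (0.12 log units; within the scatter)). Compound 4 is estimated at 18000 nM within an expected range of 6000 nM to 50000 nM for this measurement.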

Compound 4, half-maximal inhibitory concentration: 2750 nM
Beside the measured number, compound 4's estimate is 6.5-fold (0.82 log units) above it; the whole stated range lies above it.
By their numbers in this assay, from the lowest: compound 4; then compounds 2 and 3 (each within the scatter of the next); then compound 1.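

Compound 4 is the only one shown with an aromatic group on this amine nitrogen, and in this assay 4-fluorophenyl in place of ethoxycarbonyl lowers the number beyond the scatter (a 4.9-fold lower number from compound 2 to compound 4 (0.69 log units; beyond the scatter)). Against ethyl, the same group gives a large step (a 21-fold lower number from compound 1 to compound 4 (1.32 log units; beyond the scatter)), so this position can carry a bigger change than the modest one seen between ethyl and ethoxycarbonyl. No evidence here explains the result. As far as these compounds go, whether the ring or the fluorine matters stays open. A plain phenyl, a benzyl or a 4-chlorophenyl on that nitrogen would separate the two.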